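Sulfonyl aryl swap on an indole-imidazoline kallikrein-7 inhibitor

The compounds below may be only part of what the source reports. "The series", "measured", "known", "first", "only" and "open" are said of these compounds alone.

Of the compounds shown here, two have numbers so far. Compound 1 `Cc1ccc(S(=O)(=O)n2cc(C3CNC(C(C)C)=N3)c3ccccc32)cc1` gives 70000 nM in an assay on isolated protein for inhibition of kallikrein-7 (Homo sapiens), read by fluorescence, with stated times of 10 min and 30 min; a higher number here means a weaker inhibitor, a lower number a stronger inhibitor. Compound 2 `CC1=NC(c2cn(S(=O)(=O)c3ccc(F)cc3)c3ccc(C)cc23)CN1` gives 9400 nM in this assay, the lowest of the two numbers; compound 1 sits at a higher number, and that gap is beyond the scatter. The two structures differ in more than one place, so their values are simply compared side by side.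

The next compound, compound 3 `CC1=NC(c2cn(S(=O)(=O)c3ccccc3Br)c3ccc(C)cc23)CN1`, is built from compound 2 by one change: 2-bromophenyl in place of 4-fluorophenyl on a sulfonyl sulfur. Among the measured compounds shown here, no pair among the measured compounds shows such a swap, so nothing here tells how large it will be. The author expects the step from compound 2 to compound 3 to stay within the scatter, the direction being open, as a 1.3-fold higher number from compound 2 to compound 3 (0.11 log units; within the scatter). For compound 3 the author therefore estimates 12000 nM in this assay, within a range from 4000 nM to 40000 nM.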

Compound 3, half-maximal inhibitory concentration: 390 nM
Beside the measured number, compound 3's estimate is 31-fold (1.49 log units) above it, and the stated range ends above it.
By their numbers in this assay, from the lowest: compound 3; then compound 2; then compound 1.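

In this assay, 2-bromophenyl in place of 4-fluorophenyl on a sulfonyl sulfur gives a 24-fold lower number from compound 2 to compound 3 (1.38 log units; beyond the scatter), the first one-place comparison among these compounds, and it shows that the aryl group at this position can move the number by a large step. The two groups match in heavy-atom count, in their ring, in hydrogen-bond donors and acceptors and in net charge, so those counts do not separate them, and what differs is the halogen and where it stands on the phenyl ring. No measurement offered here accounts for the size of the step.

The compounds shown leave open whether the halogen or its place on the ring carries the step, a question that 4-bromophenyl or 2-fluorophenyl would separate. They also leave open how 2-chlorophenyl or 2-methylphenyl would behave on the same sulfonyl sulfur.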